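Chloroethyl amide replacing a carboxyethenyl amide

The source may report more compounds than this note shows. Statements on the series, on what has been measured and on what is new or still open speak of the compounds shown alone.

Two compounds have been run in an ADME assay on BJ cells (Homo sapiens) for inhibition, with a stated time of 72 h; a lower number here means that less compound is needed, a higher number that more compound is needed for the effect. Compound 1 `O=C(Nc1ccc(Cl)cc1)c1cc([N+](=O)[O-])ccc1Cl` returns only a limit of the assay, > 25000 nM. Compound 2 `O=C(O)/C=C/C(=O)Nc1cccc(-c2nc3ccccc3s2)c1` likewise returns only a limit, > 25000 nM. Among the compounds with values here, both values therefore sit at the limit of > 25000 nM in this assay, at which 2 of the 2 values shown sit, so compound 2 stands where every measured value of the series stands, and no step between measured compounds is available to size a change.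

Compound 3 `CC(Cl)C(=O)Nc1cccc(-c2nc3ccccc3s2)c1` is to be measured in this assay. It differs from compound 2 by 1-chloroethyl in place of 2-carboxyethenyl on a carbonyl carbon.

Within the data shown here, with no measured step to lean on, the expectation can only be framed loosely. A step of moderate size toward a lower number is expected as an at least 2.0-fold lower number from compound 2 to compound 3 (0.31 log units; beyond the scatter), though a value remaining at the limit would not be surprising. Compound 3 is accordingly estimated at 12000 nM, with a range from 2500 nM to 25000 nM.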

Compound 3, half-maximal effective concentration: > 25000 nM
Compound 3: only a limit was reported; the forecaster's own chance of this, stated with the estimate: 50%; at least 2.0-fold (0.31 log units) between middle value and limit.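

In this assay compound 2 and compound 3 both return only a limit, so no step between them can be read: the limit of > 25000 nM in this assay, at which 3 of the 3 values shown sit.

The compounds shown leave open whether any group on this carbonyl carbon gives a value in this assay rather than a limit.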